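This account rests on a few compounds, and the source may have more. Where it says the series, first, only, none or still open, it means among the compounds named here.

In an ADME assay on HepG2 cells (Homo sapiens) for cytotoxicity, read by MTT assay, with a stated time of 72 h (a higher number here means that more compound is tolerated, a lower number that less compound is tolerated), compound 1 `CC1(c2ccc(-c3ccc(/C(N)=N\O)cc3)cc2)CC(S(=O)(=O)c2ccc(F)cc2)=C(c2ccc(/C(N)=N\O)cc2)O1` gives 15300 nM, the lower of the two numbers recorded, while compound 2 `CC1(Cc2ccccc2)CC(S(=O)(=O)c2ccccc2C(F)(F)F)=C(c2ccc(/C(N)=N\O)cc2)O1` gives 57500 nM, a step beyond the usual scatter. Compound 3 `COc1cc(-c2ccc(C3(C)CC(S(=O)(=O)c4ccc(F)cc4)=C(c4ccc(/C(N)=N\O)cc4)O3)cc2)cc(OC)c1OC` differs from compound 1 in one place: a group of 12 heavy atoms (9 carbon, 3 oxygen; one six-membered aromatic ring of carbon only) in place of a group of 10 heavy atoms (7 carbon, 2 nitrogen, 1 oxygen; one six-membered aromatic ring of carbon only), on an aromatic carbon. Going by the values given here, no measured pair shows this exact change, so the step from compound 1 to compound 3 in this assay has no direct precedent. A small decrease, or none beyond the scatter, is expected, a 1.4-fold lower number from compound 1 to compound 3 (0.14 log units; within the scatter). For compound 3 the expected value in this assay is 11000 nM, with a range from 4000 nM to 35000 nM.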

Compound 3, half-maximal cytotoxic concentration: > 50000 nM
Compound 3: only a limit was reported; the forecaster's own chance of this, stated with the estimate: 10%; middle value at least 4.5-fold (0.65 log units) away from the limit.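

In this assay, 3,4,5-trimethoxyphenyl on this aromatic carbon, para to a large group, gives an at least 3.2-fold higher number from compound 1 to compound 3 (0.51 log units; beyond the scatter). Going by these compounds alone, this shows that the reading responds to the group at this position, which the earlier compounds could not show, since they differ in more than one place. From the compounds shown here alone, the upper end of the step stays unknown, as compound 3 stands at a limit and not a number: the limit of > 50000 nM in this assay, at which 1 of the 3 values shown sits.

Going by these compounds, whether the three methoxy groups or the loss of the leaving group drives the step stays open. So does how an unsubstituted phenyl, an amine or a carboxylic acid would read at this position.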